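From ethynyl to furan-3-yl on compound 3

The compounds below may be only part of what the source reports. "The series", "measured", "known", "first", "only" and "open" are said of these compounds alone.

Compound 1 `Cc1noc(Cn2nnc3c(C(N)=O)ncn3c2=O)n1` reads > 50000 nM in a functional assay on U-373MG ATCC cells for inhibition, with U373 MG (Homo sapiens) as the target, read by MTT assay, with a stated time of 7 days (on this read-out higher numbers stand for weaker inhibition of growth and lower numbers for stronger inhibition of growth), which is a limit of the assay and not a number. Compound 2 `COc1ccc([C@@H](C)n2nnc3c(C(N)=O)ncn3c2=O)cc1` reads > 50000 nM in this assay, again a limit. Going by the values given here, compound 3 `C#CC/N=N/Nc1[nH]cnc1C(N)=O` gives 32000 nM, the only true number so far, so it stands alone as the reference point, with no measured step available for calibration.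

Next comes compound 4 `NC(=O)c1nc[nH]c1N/N=N/Cc1ccoc1`, in which furan-3-yl replaces ethynyl on a saturated chain carbon bound to a double-bonded nitrogen: furan-3-yl in place of ethynyl on a saturated chain carbon bound to a double-bonded nitrogen. Among the compounds with values here, no measured pair shows what such a change does. The expectation in this assay is therefore no shift beyond the usual scatter, an expectation anchored only on compound 3 at 32000 nM. The estimated change is a 1.1-fold lower number from compound 3 to compound 4 (0.03 log units; within the scatter). For compound 4 the estimated value is 30000 nM, with an expected range of 12000 nM to 50000 nM.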

Compound 4, concentration for 50% growth inhibition: > 50000 nM
Compound 4 ended at the assay's limit (the forecaster's own chance of this, stated with the estimate: 25%); at least 1.6-fold (0.22 log units) between middle value and limit.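

In this assay compound 4 gives > 50000 nM, which is a limit of the assay and not a number. The change on a saturated chain carbon bound to a double-bonded nitrogen, furan-3-yl in place of ethynyl, gives the series its first step: an at least 1.5-fold higher number from compound 3 to compound 4 (0.19 log units; that floor lies within the scatter); this shows no sign of stronger inhibition of growth, and only a floor is available for its size. Going by these compounds alone, compound 3 remains the only compound with a true number, and the step cannot be sized further: the limit of > 50000 nM in this assay, at which 3 of the 4 values shown sit.

From the compounds shown here alone, whether furan-3-yl truly weakens inhibition of growth relative to ethynyl or stays within the scatter remains open. Also open, going by these compounds, is whether a phenyl ring, a longer alkyl chain or an amine at this place would give a lower number than compound 3.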